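Hydroxyalkyl carbonate chain length and half-life

A few compounds are considered here, and "the series" means these few. Any claim that something is new, unique, unknown or untested is made for them only; others in the source may bear on it.

Measured compounds:
compound 1 `Cc1cn(C2CC(N=[N+]=[N-])C(COC(=O)OCCCCO)O2)c(=O)[nH]c1=O`: 0.5 h
compound 2 `Cc1cn(C2CC(N=[N+]=[N-])C(COC(=O)OCCCCCO)O2)c(=O)[nH]c1=O`: 0.267 h

In an ADME assay for pharmacokinetics (on this read-out higher numbers stand for a longer-lived compound and lower numbers for a shorter-lived compound), compound 2 stands alongside compound 1, the two numbers within the scatter of each other. Compound 3 `Cc1cn(C2CC(N=[N+]=[N-])C(COC(=O)OCCCCCCCCO)O2)c(=O)[nH]c1=O` differs from compound 2 by 3-hydroxypropyl in place of hydroxy on a saturated chain carbon, five bonds along the chain from an oxygen next to a carbonyl group. Among the compounds with values here, the one measured step bearing on this change, a 1.9-fold lower number from compound 1 to compound 2 (0.27 log units; within the scatter), lengthened the same chain and stayed within the scatter. A further lengthening is therefore expected to move this assay by no more than the scatter. Compound 3 is estimated at 0.25 h, range 0.1 h to 0.6 h, an expected step of a 1.1-fold lower number from compound 2 to compound 3 (0.03 log units; within the scatter).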

Compound 3, half-life: 0.0333 h
Estimate against measurement, compound 3: 7.5-fold (0.88 log units) above; measured number below the stated range.
By their numbers in this assay, from the lowest: compound 3; then compounds 2 and 1 (each within the scatter of the next).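

In this assay, 3-hydroxypropyl in place of hydroxy on this saturated chain carbon gives an 8.0-fold lower number from compound 2 to compound 3 (0.90 log units; beyond the scatter) and so moves the number clearly, which the earlier chain step did not do. Read as 4-hydroxybutyl in place of hydroxy, the change gives a 15-fold lower number from compound 1 to compound 3 (1.18 log units; beyond the scatter) across the three compounds, with the longest chain at the bottom of the series. Nothing available explains this fall.

Still open, as far as these compounds go, is whether a longer chain lowers the number further. Also open, from the compounds shown here alone, is how a carboxylic acid or an amine in place of the hydroxy would read on this chain.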